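Bromo to chloro on two related indole-bearing cores

The source may hold more compounds than are shown below. What is called first, only, known or untested is meant among the compounds shown, and "the series" means these compounds.

Compound 1 `COC(=O)[C@@]1(C)CCC=C2[C@@H]1CC[C@@H](C)[C@]2(C)Cc1c(C)[nH]c2c(Br)cccc12`: 38000 nM
Compound 2 `COC(=O)[C@@]1(C)CCC=C2[C@@H]1CC[C@@H](C)[C@]2(C)Cc1c(C)[nH]c2c(Cl)cccc12`: 29000 nM
Compound 3 `COC(=O)[C@@]1(C)CC[C@@H]2C3=C1CC[C@@H](C)[C@]3(C)Cc1c2[nH]c2c(Br)cccc12`: 37000 nM

In a functional assay on WiDr cells (Homo sapiens) for inhibition, read by sulforhodamine B assay, with a stated time of 48 h (a lower number here means a stronger inhibitor of growth, a higher number a weaker inhibitor of growth), compound 1 gives 38000 nM and compound 2 gives 29000 nM. Compound 2 differs from compound 1 by chloro in place of bromo on an aromatic carbon and this change brought a 1.3-fold lower number from compound 1 to compound 2 (0.12 log units; within the scatter). Compound 3 gives 37000 nM in this assay; the difference between the core of compound 3 and the core of compound 1 is not broken down here.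

Compound 4 `COC(=O)[C@@]1(C)CC[C@@H]2C3=C1CC[C@@H](C)[C@]3(C)Cc1c2[nH]c2c(Cl)cccc12` has not yet been tested. It differs from compound 3 by chloro in place of bromo on an aromatic carbon. This is the same kind of change as that from compound 1 to compound 2, though the ring the halogen sits on is part of a fused or bridged system of two rings in compound 1 and of five rings in compound 3. Because the earlier step was a 1.3-fold lower number from compound 1 to compound 2 (0.12 log units; within the scatter), the step from compound 3 to compound 4 in this assay is expected to be about as small: a 1.2-fold lower number from compound 3 to compound 4 (0.09 log units; within the scatter). Compound 4 is therefore estimated at 30000 nM, with a likely range from 15000 nM to 60000 nM.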

Compound 4, concentration for 50% growth inhibition: 21000 nM
Compound 4: middle estimate off by 1.4-fold (0.15 log units), on the high side; low and high end bracket the measured number.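

In this assay, chloro in place of bromo on the aromatic carbon gives a 1.8-fold lower number from compound 3 to compound 4 (0.25 log units; within the scatter), and the same change on the other core gives a step that cannot be told apart from it: the same change on two cores in this assay, a 1.3-fold lower number (0.12 log units; within the scatter) from compound 1 to compound 2 and a 1.8-fold lower number (0.25 log units; within the scatter) from compound 3 to compound 4, 1.3-fold (0.13 log units) apart, within the scatter of two such steps. On these two cores, then, the change carries over in a plain sense: it stays small on both, and neither step rises above the ordinary spread of repeated measurements. This does not show that the choice between the two halogens matters for growth inhibition, nor that a third core would behave alike; only two pairs are shown.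

The compounds shown carry only bromo or chloro at this place, which leaves open whether a different group there, such as an amine, a methoxy group or a carboxylic acid, would shift the number beyond the scatter on either core. Going by these compounds, it also remains open how a carboxylic acid or an amide would fare in place of the methyl ester that all four compounds share.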